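Halogens Replacing Nitro on the Cinnamoyl Aryl Ring

The source may hold more compounds than are shown below. What is called first, only, known or untested is meant among the compounds shown, and "the series" means these compounds.

Compound 3 `CNC(=O)c1cc(Oc2ccc(C(=O)/C=C/c3ccc([N+](=O)[O-])cc3)cc2)ccn1` was tested in a functional assay on A549 cells (Homo sapiens) for cytotoxicity, read by MTT assay, with a stated time of 72 h (a lower number here means a stronger inhibitor, a higher number a weaker inhibitor), and gave only a limit: for compound 3 the result is > 50000 nM, which is the limit of > 50000 nM in this assay, at which 1 of the 3 values shown sits. The two measured analogues give numbers: compound 1 `CNC(=O)c1cc(Oc2ccc(C(=O)/C=C/c3ccc(C#N)cc3)cc2)ccn1` gives 26400 nM, and compound 2 `CNC(=O)c1cc(Oc2ccc(C(=O)/C=C/c3ccc(F)cc3)cc2)ccn1` gives 18600 nM. Compound 4 `CNC(=O)c1cc(Oc2ccc(C(=O)/C=C/c3ccc(Cl)c(Cl)c3)cc2)ccn1` changes the same ring again, with 3,4-dichlorophenyl in place of 4-nitrophenyl on a double-bonded chain carbon bound to a double-bonded chain carbon. Among the measured compounds shown here, the steps that bear on it are an at least 1.8-fold higher number from compound 1 to compound 3 (0.27 log units; that floor lies within the scatter) and an at least 2.6-fold higher number from compound 2 to compound 3 (0.42 log units; beyond the scatter), both moving toward a higher number with the nitro group in place. Returning to halogens on that ring, compound 4 is therefore expected to give a lower number than its nitro parent, a step of an at least 3.3-fold lower number from compound 3 to compound 4 (0.52 log units; beyond the scatter). The estimate for compound 4 is 15000 nM, within a range from 5000 nM to 50000 nM.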

Compound 4, half-maximal inhibitory concentration: 33700 nM
Estimate against measurement, compound 4: 2.2-fold (0.35 log units) below; measured number inside the range.
By their numbers in this assay, from the lowest: compounds 2, 1 and 4 (each within the scatter of the next). At a limit, above all of these: compound 3.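

With 3,4-dichlorophenyl on this double-bonded chain carbon, the result gives no more than a floor, since compound 3 gives only a limit, not a number: the limit of > 50000 nM in this assay, at which 1 of the 4 values shown sits. That floor, an at least 1.4-fold lower number from compound 3 to compound 4 (0.17 log units; that floor lies within the scatter), does not match the clear separation of nitro from fluoro seen earlier. Against the other aryl groups the change gives a 1.8-fold higher number from compound 2 to compound 4 (0.26 log units; within the scatter) and a 1.3-fold higher number from compound 1 to compound 4 (0.11 log units; within the scatter), so 4-fluorophenyl, 4-cyanophenyl and 3,4-dichlorophenyl remain unseparated here.

Going by these compounds, the true size of the step from compound 3 stays open. So does whether an amine or a carboxylic acid on that ring would separate from compounds 1, 2 and 4.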